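The source may hold more compounds than are shown below. What is called first, only, known or untested is meant among the compounds shown, and "the series" means these compounds.

Measured compounds:
Compound 1 `CC#C[C@@H](CC(=O)O)c1ccc(OC[C@H]2COc3cccc(Cl)c3O2)cc1` gives 520 nM in a functional assay on HEK293 cells for agonist activity at Free fatty acid receptor 1 (Homo sapiens), read by fluorescence and calcium flux, with a stated time of 10 min; on this read-out lower numbers stand for an effect already at smaller amounts and higher numbers for an effect only at larger amounts of compound.
Compound 2 `CC#C[C@@H](CC(=O)O)c1ccc(OC[C@H]2COc3ccccc3O2)cc1` gives 90 nM in this assay.

Among the compounds with values here, compound 2 holds the lowest of the two numbers in this assay; its only neighbour is compound 1, and the step of a 5.8-fold lower number from compound 1 to compound 2 (0.76 log units; beyond the scatter) lies beyond the scatter. Compound 3 `CC#C[C@@H](CC(=O)O)c1ccc(OC[C@H]2COc3ccc(OC)cc3O2)cc1` has not yet been measured in this assay. It differs from compound 2 by methoxy in place of hydrogen on an aromatic carbon. Within the data shown here, the one measured step, a 5.8-fold lower number from compound 1 to compound 2 (0.76 log units; beyond the scatter), concerns a chloro group on the same part of the shared core and shows that a substituent there raised the number, yet the methoxy of compound 3 enters at another place, so that step bears on the present case only loosely. A modest rise in the number is therefore expected for compound 3, estimated as a 2.2-fold higher number from compound 2 to compound 3 (0.35 log units; beyond the scatter). Compound 3 is expected to give 200 nM in this assay, with a range from 60 nM to 700 nM.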

Compound 3, half-maximal effective concentration: 130 nM
Estimate against measurement, compound 3: 1.5-fold (0.19 log units) above; low and high end bracket the measured number.
By their numbers in this assay, from the lowest: compounds 2 and 3 (each within the scatter of the next); then compound 1.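

In this assay, methoxy in place of hydrogen on an aromatic carbon gives a 1.4-fold higher number from compound 2 to compound 3 (0.16 log units; within the scatter), so at this position the change cannot be told apart from the scatter. Within the data shown here, the only earlier step, a 5.8-fold lower number from compound 1 to compound 2 (0.76 log units; beyond the scatter), lay beyond the scatter and concerned a chloro group at another place on the same part of the shared core, so the new result shows that a substituent on this part does not always go with a number beyond the scatter of the unsubstituted compound 2. No available evidence bears on the reason for this result.

The compounds shown leave open whether the difference between the two steps belongs to the group or to its place, as chloro and methoxy sit at different places. They also leave open how an amine, a hydroxyl group or a longer ethoxy chain would behave at the methoxy position.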